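A few compounds are considered here, and "the series" means these few. Any claim that something is new, unique, unknown or untested is made for them only; others in the source may bear on it.

Compound 1, with the structure `O=C1CC(c2nc(-c3cccc(Cl)c3)no2)CN1c1ccccc1Cl`, was tested in an in vitro functional assay on HEK293-A cells for positive allosteric modulation of metabotropic glutamate receptor 5 (Homo sapiens), read by FLIPR and calcium flux; a higher number here means that more compound is needed for the effect, a lower number that less compound is needed. Compound 1 gives > 10000 nM, which is a limit of the assay rather than a measured number. Two further compounds have been run in this assay. Compound 2, `Cc1ccc(N2CC(c3nc(-c4cccc(C)c4)no3)CC2=O)cc1`, gives 1300 nM in this assay. Compound 3, `O=c1sc2ccccc2n1Cc1nc(-c2cccc(Cl)c2)no1`, gives > 10000 nM, again only a limit of the assay. Compound 1 therefore stands at the limit of > 10000 nM in this assay, at which 2 of the 3 values shown sit, and no firm number places it against compound 2.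

Compound 4, `O=C1CC(c2nc(-c3cccc(Cl)c3)no2)CN1c1cccc(Cl)c1`, has not yet been measured. It differs from compound 1 in a single way: 3-chlorophenyl in place of 2-chlorophenyl on an amide-type nitrogen in a ring, the 3-chlorophenyl taking the place of the 2-chlorophenyl on an amide-type nitrogen in a ring. Going by the values given here, no measured pair shows this exact change, so its size is uncertain; compound 2, which carries a different group on that same nitrogen and gives 1300 nM, shows that a measurable value on this core is possible. In this assay the expected step is an at least 4.0-fold lower number from compound 1 to compound 4 (0.60 log units; beyond the scatter), toward less compound needed. Compound 4 is estimated at 2500 nM, with a range from 600 nM to 10000 nM.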

Compound 4, half-maximal effective concentration: > 10000 nM
Compound 4: no number, only a limit (the forecaster's own chance of this, stated with the estimate: 35%); at least 4.0-fold (0.60 log units) between middle value and limit.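

In this assay compound 4 gives > 10000 nM, a limit of the assay and not a number. Going by these compounds alone, compound 1 also stands at a limit, so no step from compound 1 to compound 4 can be read. Most of the series now sits there: the limit of > 10000 nM in this assay, at which 3 of the 4 values shown sit.

The compounds shown leave open whether 3-chlorophenyl or 2-chlorophenyl on the amide-type nitrogen gives the lower number.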